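The compounds below may be only part of what the source reports. "The series", "measured", "known", "first", "only" and "open" are said of these compounds alone.

Among the compounds with values here, in an ADME assay on cells (Hepatocyte, Homo sapiens) for metabolic stability, with a stated time of 30 min (on this read-out higher numbers stand for a more stable compound and lower numbers for a less stable compound), compound 2 `O=C(OC1CCC(CN2CCN(c3cc(=O)c4cc(C(F)(F)F)cc([N+](=O)[O-])c4s3)CC2)CC1)C1CCCCC1` gives 2.8%, the lower of the two numbers so far, while compound 1 `NC1CCC(CN2CCN(c3cc(=O)c4cc(C(F)(F)F)cc([N+](=O)[O-])c4s3)CC2)CC1` gives 83.6%. Compound 3 `O=c1cc(N2CCN(CC3CCCCC3)CC2)sc2c([N+](=O)[O-])cc(C(F)(F)F)cc12` differs from compound 2 by one change: hydrogen in place of (cyclohexylcarbonyl)oxy on a saturated ring carbon. Within the data shown here, one measured step bears on this change, the large a number 80.8 percentage points lower from compound 1 to compound 2 (beyond the scatter), which put (cyclohexylcarbonyl)oxy on that same ring carbon in place of amino. Removing that group is therefore expected to recover much of the drop, although hydrogen is not amino and the recovery may be partial. The expected rise is a number 47.2 percentage points higher from compound 2 to compound 3 (beyond the scatter). Compound 3 is estimated at 50%, with an expected range of 20% to 82%.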

Compound 3, percent of the compound remaining: 82.4%
Beside the measured number, compound 3's estimate is 32.4 percentage points below it; the whole stated range lies below it.
By their numbers in this assay, from the lowest: compound 2; then compounds 3 and 1 (each within the scatter of the next).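

Hydrogen in place of (cyclohexylcarbonyl)oxy gives a number 79.6 percentage points higher from compound 2 to compound 3 (beyond the scatter) in this assay, so the low number goes with this group and not with the shared core. Hydrogen in place of amino gives a number 1.2 percentage points lower from compound 1 to compound 3 (within the scatter), so hydrogen and amino cannot be told apart on this saturated ring carbon. The amino group is therefore not needed for the high number.

Going by these compounds, whether a hydroxyl group, an acetyl ester or a carboxylic acid on this carbon would keep the number high stays open. Nothing given here explains why the (cyclohexylcarbonyl)oxy compound stands so low.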